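A few compounds are considered here, and "the series" means these few. Any claim that something is new, unique, unknown or untested is made for them only; others in the source may bear on it.

Measured compounds:

- compound 1, `C=C(Br)C(=O)Nc1cccc(-c2cn3nc(CCc4ccccc4)sc3n2)c1`: 3300 nM
- compound 2, `Nc1cccc(-c2cn3nc(Cc4ccc(Cl)cc4)sc3n2)c1`: 25000 nM
- compound 3, `CCc1ccc(-c2nn3cc(-c4cccc(N)c4)nc3s2)cc1`: 8100 nM

All three were tested in a functional assay on HeLa cells (Homo sapiens) for inhibition, read by cell counting, with a stated time of 4 days; on this read-out lower numbers stand for stronger inhibition and higher numbers for weaker inhibition. Compound 1 stands at the lowest number of the three, and its gaps to compound 3 and to compound 2 both lie beyond the usual scatter of the measurement, so on these numbers compound 1 is the strongest inhibitor of the set. Compound 2 and compound 3 differ from compound 1 in more than one place at once, so nothing can be read from them about any single change.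

Compound 4, `C=C(Br)C(=O)Nc1cccc(-c2cn3nc(Cc4ccccc4)sc3n2)c1`, has not yet been measured. It keeps everything in compound 1 except one group: phenyl in place of benzyl on a saturated chain carbon bound to an aromatic carbon. The shared core and the rest of the molecule stay the same. Going by the values given here, no measured pair in this set isolates that change, so there is no direct guide to its effect; the expectation rests only on the fact that the change is small and the rest of compound 1 is kept. The step of a 1.1-fold higher number from compound 1 to compound 4 (0.03 log units; within the scatter) is therefore expected to be modest, most likely within the scatter of repeated measurement, with no clear direction. Compound 4 is estimated to give about 3500 nM in this assay, expected to fall between 1200 nM and 10000 nM.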

Compound 4, half-maximal inhibitory concentration: 4500 nM
For compound 4 the middle estimate is 1.3-fold (0.11 log units) below the measured one, and the stated range covers the measured number.
By their numbers in this assay, from the lowest: compounds 1, 4 and 3 (each within the scatter of the next, the first and the last beyond it); then compound 2.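

In this assay, trading the phenethyl group for benzyl while keeping the rest of the molecule gives a 1.4-fold higher number from compound 1 to compound 4 (0.13 log units; within the scatter) and so the two compounds cannot be told apart by this measurement. Going by these compounds alone, this is the first pair in the set that differs in this one place, which the earlier compounds could not show, and it indicates that the chain at this position can lose one carbon without a difference this assay can resolve. No further measurement is available to explain this result, so it remains a plain observation about these two compounds.

The compounds shown leave open how far this tolerance extends, for example whether a longer chain such as phenylpropyl, or a carboxylic acid or an amine on the outer ring, would give a number beyond the scatter. They also leave open what the bromoacrylamide end contributes, since no pair shown changes that end alone.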